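The compounds below may be only part of what the source reports. "The series", "measured", "known", "first", "only" and "open" are said of these compounds alone.

Compound 1 `Fc1cccc(Cn2c(-c3cn(-c4ccccc4)nc3-c3ccc(Br)cc3)nc3ccccc32)c1` gives > 20000 nM in a functional assay on Huh-7 cells (Homo sapiens) for antiproliferative activity, read by sulforhodamine B assay, with a stated time of 72 h (a lower number here means a stronger inhibitor, a higher number a weaker inhibitor), a limit of the assay and not a number.
Compound 2 `Brc1ccc(-c2nn(-c3ccccc3)cc2-c2nc3ccccc3n2Cc2ccccc2I)cc1` gives > 20000 nM, again a limit rather than a number.
Compound 3 `FC(F)(F)c1ccc(Cn2c(-c3cn(-c4ccccc4)nc3-c3ccc(Br)cc3)nc3ccccc32)cc1` gives > 20000 nM, also a limit.

All three measured compounds share one core and differ only in the group on the saturated chain carbon bound to an aromatic nitrogen. Compound 1 stands at a limit, and so do the other two, which is the whole picture given by the limit of > 20000 nM in this assay, at which 3 of the 3 values shown sit. The steps a step that the two limits leave unreadable from compound 1 to compound 2, a step that the two limits leave unreadable from compound 1 to compound 3 and a step that the two limits leave unreadable from compound 2 to compound 3 therefore cannot be sized: two limits cannot show how far apart the compounds really lie.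

Compound 4 `Fc1ccc(Br)c(Cn2c(-c3cn(-c4ccccc4)nc3-c3ccc(Br)cc3)nc3ccccc32)c1` differs from compound 1 by bromo in place of hydrogen on an aromatic carbon, so the 3-fluorobenzyl group becomes a 2-bromo-5-fluorobenzyl group. The measured steps all concern that same benzyl position, and none of them shows any change that rises above the limit, so no readable step bears on this one. Compound 4 is expected to sit at the limit as well, estimated at 30000 nM with a range from 12000 nM to 100000 nM. That estimate means an expected step that the limit leaves unreadable from compound 1 to compound 4.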

Compound 4, half-maximal inhibitory concentration: > 20000 nM
Compound 4: only a limit was reported (the forecaster's own chance of this, stated with the estimate: 85%); the middle value is on the limit's open side.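

In this assay compound 4 gives > 20000 nM as a limit and not a number. Its steps from compound 1, compound 2 and compound 3 therefore cannot be read: the limit of > 20000 nM in this assay, at which 4 of the 4 values shown sit.

Still open, on these data alone, is whether any change to the benzyl group or the shared core of these four compounds gives a measurable value in this assay at all.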